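The source may hold more compounds than are shown below. What is called first, only, known or untested is meant among the compounds shown, and "the series" means these compounds.

Compound 2 `CC1=C(C(=O)Nc2ccc(F)cc2)C(c2ccc(Br)cc2)n2c(s/c(=C/c3ccccc3)c2=O)=N1` gives 5% in a functional assay on the whole organism (strain albino) for inhibition, with Rattus norvegicus as the target, read by paw edema, with stated times of 1 h and 3 h, at a dose of 25 mg/kg by the oral route (a higher number here means more inhibition at the dose given (going by the name of the read-out), a lower number less inhibition), the lowest of the three numbers shown, though compound 1 `COc1ccc(/C=c2/sc3n(c2=O)C(c2ccc(Br)cc2)C(C(=O)Nc2ccc(F)cc2)=C(C)N=3)cc1OC` with 8% and compound 3 `CC1=C(C(=O)Nc2ccc(F)cc2)C(c2ccc(Br)cc2)n2c(s/c(=C/c3ccc(C)cc3)c2=O)=N1` with 11% both stand within the scatter of it. The measured steps of a number 3 percentage points lower from compound 1 to compound 2 (within the scatter), a number 3 percentage points higher from compound 1 to compound 3 (within the scatter) and a number 6 percentage points higher from compound 2 to compound 3 (within the scatter) were all within the scatter. Compound 4 `CC1=C(C(=O)Nc2ccc(F)cc2)C(c2ccc([N+](=O)[O-])cc2)n2c(s/c(=C/c3ccccc3)c2=O)=N1` differs from compound 2 in one place: nitro in place of bromo on an aromatic carbon. Among the compounds with values here, no measured step bears directly on this change; the measured steps sit on another part of the molecule, and none of them moved the read-out beyond the scatter. The step of a number 2 percentage points higher from compound 2 to compound 4 (within the scatter) is therefore expected to stay within the scatter in this assay. Compound 4 is estimated at 7%, between 0% and 20%.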

Compound 4, a percentage reported as inhibition, in the whole organism at one dose (the size of the read-out at that dose, not a potency): 7%
Compound 4: the middle estimate sits on the measured number at the digits printed; the measured number falls inside the stated range.
By their numbers in this assay, from the lowest: compounds 2, 4, 1 and 3 (each within the scatter of the next).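

In this assay the change from 4-bromophenyl to 4-nitrophenyl gives a number 2 percentage points higher from compound 2 to compound 4 (within the scatter) and is the only step shown at this aromatic position. Within the data shown here, exchanging bromo for the larger nitro, which adds hydrogen-bond acceptors, thus leaves the read-out unchanged within the scatter at this position, as the earlier steps did on the other aryl group. No evidence accounts for this flat result.

Going by these compounds, whether an amine or a carboxylic acid at this position would move the read-out remains open. So does whether nitro would behave the same way alongside the 3,4-dimethoxyphenyl or 4-methylphenyl groups.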